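This account rests on a few compounds, and the source may have more. Where it says the series, first, only, none or still open, it means among the compounds named here.

Measured compounds:

Compound 1, `COc1ccc(Oc2ccc3c(NCCCNCc4cc(F)ccc4OC)ccnc3c2)cc1`: 9.28
Compound 2, `Fc1ccc(-c2ccc3c(NCCCNCc4ccco4)ccnc3c2)cc1`: 9.47
Compound 3, `COc1ccc(F)cc1CNCCCNc1ccnc2cc(-c3ccc(F)cc3)ccc12`: 9.47

All three were examined in a physicochemical assay for acid dissociation. Compound 2 and compound 3 stand together at the top of these three numbers, showing no change at the digits printed from compound 2 to compound 3 (within the scatter). Among the compounds with values here, compound 1 and compound 2 have no single-point step between them; their two values differ by an amount that lies within the usual scatter of this assay, so nothing separates them either.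

Compound 4, `c1coc(CNCCCNc2ccnc3cc(CC4CCCCC4)ccc23)c1`, is not yet measured. It differs from compound 2 as follows: cyclohexylmethyl in place of 4-fluorophenyl on an aromatic carbon.

Within the data shown here, two measured steps bear on this. The step with a number 0.19 log units higher from compound 1 to compound 3 (within the scatter) swapped a group at the same aromatic carbon of the shared core and stayed within the scatter. The step with no change at the digits printed from compound 2 to compound 3 (within the scatter) swapped a group at the other end of the chain, and it too stayed within the scatter. With every change so far leaving this assay flat, the swap to cyclohexylmethyl is expected to do the same: no step beyond the scatter, in either direction.

Compound 4 is therefore estimated at 9.45, with a range from 9.15 to 9.75. This estimate means a step of a number 0.02 log units lower from compound 2 to compound 4 (within the scatter), expected to sit inside the scatter.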

Compound 4, acid dissociation constant: 9.47
Beside the measured number, compound 4's estimate is 0.02 log units below it, and the stated range covers the measured number.
By their numbers in this assay, from the lowest: compounds 1, 2, 3 and 4 (each within the scatter of the next).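

In this assay, putting cyclohexylmethyl in place of 4-fluorophenyl on this aromatic carbon gives no change at the digits printed from compound 2 to compound 4 (within the scatter) and so adds a new kind of swap: a six-membered aromatic ring of carbon only gives way to a six-membered non-aromatic ring of carbon only, with 7 heavy atoms in each group and the fluorine gone. The earlier step at this carbon, a number 0.19 log units higher from compound 1 to compound 3 (within the scatter) in the same assay, exchanged one group holding an aromatic ring for another, so it could not show what happens when that ring is lost. For compound 2 and compound 4, the reading stays within the scatter without an aromatic ring in this group, and nothing shown explains why.

From the compounds shown here alone, both groups in the new step carry no net charge and count no hydrogen-bond donors or acceptors, so it remains open whether an amine or a carboxylic acid on this aromatic carbon would also stay within the scatter. Also open, going by these compounds, is whether a longer chain joining the two nitrogens of the shared core and its side arm would leave this assay just as undisturbed.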